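Moving the fluorine on the sulfonyl aryl group

This account rests on a few compounds, and the source may have more. Where it says the series, first, only, none or still open, it means among the compounds named here.

Compound 3 `O=C(NCc1ccc(CNS(=O)(=O)c2ccc(F)cc2)cc1)c1ccc(F)cc1` gives the lowest number of the three measured compounds in an assay on MDA-MB-231 cells for binding affinity to C-X-C chemokine receptor type 4 (Homo sapiens), read by fluorescence and microscopy, with stated times of 10 min and 30 min (a lower number here means that less compound is needed, a higher number that more compound is needed for the effect), at 1 nM. Compound 1 `Cc1ccccc1S(=O)(=O)NCc1ccc(CNC(=O)c2ccc(F)cc2)cc1` gives 100 nM and compound 2 `O=C(NCc1ccc(CNS(=O)(=O)c2ccc([N+](=O)[O-])cc2)cc1)c1ccc(F)cc1` gives 1000 nM. The steps of a 100-fold lower number from compound 1 to compound 3 (2.00 log units; beyond the scatter) and a 1000-fold lower number from compound 2 to compound 3 (3.00 log units; beyond the scatter) show that changing the aryl group on the sulfonyl sulfur moves this assay strongly, while a 10-fold higher number from compound 1 to compound 2 (1.00 log units; beyond the scatter) is smaller. Compound 4 `O=C(NCc1ccc(CNS(=O)(=O)c2cccc(F)c2)cc1)c1ccc(F)cc1` differs from compound 3 by 3-fluorophenyl in place of 4-fluorophenyl on a sulfonyl sulfur. Among the compounds with values here, no measured step changes only where the fluorine sits on this ring, so the direction is uncertain, but every change at the sulfonyl sulfur so far has given a higher number than compound 3. A moderate rise is therefore expected, a 10-fold higher number from compound 3 to compound 4 (1.00 log units; beyond the scatter). Compound 4 is estimated at 10 nM, within 1 nM to 100 nM.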

Compound 4, effective concentration (reported as EC, without a stated level of effect): 1000 nM
Beside the measured number, compound 4's estimate is 100-fold (2.00 log units) below it, outside the stated range (above it).
By their numbers in this assay, from the lowest: compound 3; then compound 1; then compounds 2 and 4 (each within the scatter of the next).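

In this assay, the place of one fluorine on the aryl group on the sulfonyl sulfur carries a large effect: 3-fluorophenyl in place of 4-fluorophenyl gives a 1000-fold higher number from compound 3 to compound 4 (3.00 log units; beyond the scatter) with the same atoms joined differently. The 3-fluorophenyl group shows no change at the digits printed from compound 2 to compound 4 (within the scatter) against 4-nitrophenyl and a 10-fold higher number from compound 1 to compound 4 (1.00 log units; beyond the scatter) against 2-methylphenyl, so the low number belongs to the 4-fluorophenyl group alone among these four. Nothing given here accounts for this effect. On these data alone, whether chloro, methoxy or an amine in place of the fluorine on the 4-fluorophenyl group would keep the low number stays open.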